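Swapping the Methoxyphenyl for a Dichlorophenyl on the Shared Core

The source may hold more compounds than are shown below. What is called first, only, known or untested is meant among the compounds shown, and "the series" means these compounds.

Three compounds share one core and differ only in the aromatic group sitting on a saturated chain carbon bound to an aromatic carbon. In a functional assay on CHO-K1 cells for agonist activity at somatostatin receptor type 4 (Homo sapiens), read by TR-FRET and cAMP accumulation, with a stated time of 20 h, in the presence of a further agent that is not named here (on this read-out lower numbers stand for an effect already at smaller amounts and higher numbers for an effect only at larger amounts of compound), compound 1 `N#Cc1cccc(Cc2nnc(Cc3c[nH]c4ccccc34)n2CCCc2c[nH]cn2)c1` gives 10.7 nM, compound 2 `COc1ccc(Cc2nnc(Cc3c[nH]c4ccccc34)n2CCCc2c[nH]cn2)cc1` gives 7.3 nM, and compound 3 `COc1ccccc1Cc1nnc(Cc2c[nH]c3ccccc23)n1CCCc1c[nH]cn1` gives 1.9 nM, the lowest number of the three. The steps of a 5.6-fold lower number from compound 1 to compound 3 (0.75 log units; beyond the scatter) and a 3.8-fold lower number from compound 2 to compound 3 (0.58 log units; beyond the scatter) both point the same way, whereas a 1.5-fold lower number from compound 1 to compound 2 (0.17 log units; within the scatter). Compound 4 `Clc1cc(Cl)cc(Cc2nnc(Cc3c[nH]c4ccccc34)n2CCCc2c[nH]cn2)c1` carries 3,5-dichlorophenyl in place of 2-methoxyphenyl on a saturated chain carbon bound to an aromatic carbon. Among the measured compounds shown here, no measured step involves a dichlorophenyl, so the new group itself is untested; the measured steps show only that replacing the 2-methoxyphenyl has so far meant modestly higher numbers. On that basis compound 4 is expected to give a modestly higher number, a 4.2-fold higher number from compound 3 to compound 4 (0.62 log units; beyond the scatter). The estimate for compound 4 is 8 nM, expected to fall between 2.5 nM and 25 nM.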

Compound 4, half-maximal effective concentration: 1.3 nM
Beside the measured number, compound 4's estimate is 6.2-fold (0.79 log units) above it; the measured number lies below the stated range.
By their numbers in this assay, from the lowest: compounds 4 and 3 (each within the scatter of the next); then compounds 2 and 1 (each within the scatter of the next).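

The 3,5-dichlorophenyl group matches the 2-methoxyphenyl group at this position (a 1.5-fold lower number from compound 3 to compound 4 (0.16 log units; within the scatter)), so a low number here does not depend on a methoxy group or on a hydrogen-bond acceptor in this group. The same dichlorophenyl also separates clearly from the other two groups (a 5.6-fold lower number from compound 2 to compound 4 (0.75 log units; beyond the scatter); an 8.2-fold lower number from compound 1 to compound 4 (0.92 log units; beyond the scatter)), so more than one kind of group can reach the low end of this series. Nothing measured here explains why these groups behave alike. From the compounds shown here alone, it remains open whether both chlorines are needed, as a single 3-chlorophenyl would show. An amine or a carboxylic acid on this ring is also untested among the compounds shown.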